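Opening a ring: the chain-amine analogue of compound 3

A few compounds are considered here, and "the series" means these few. Any claim that something is new, unique, unknown or untested is made for them only; others in the source may bear on it.

Compound 1, `CN(C)CCn1nc(Cc2ccc(Cl)cc2)c2ccccc2c1=O`, gives 158 nM in an assay for binding affinity to Alpha-1A adrenergic receptor (Homo sapiens); on this read-out lower numbers stand for stronger inhibition and higher numbers for weaker inhibition.
Compound 2, `CN1CCCC1CCn1nc(Cc2ccc(Cl)cc2)c2ccccc2c1=O`, gives 316 nM in this assay.
Compound 3, `CN1CCC(Cn2nc(Cc3ccc(Cl)cc3)c3ccccc3c2=O)C1`, gives 100 nM in this assay.

Compound 3 sits at the low end of these three numbers. Its gap to compound 1 is within the scatter, and only its gap to compound 2 is beyond it: a 3.2-fold lower number from compound 2 to compound 3 (0.50 log units; beyond the scatter). Compound 4, `CN(C)CCCn1nc(Cc2ccc(Cl)cc2)c2ccccc2c1=O`, keeps the shared core and differs from compound 3 in one place: 2-(dimethylamino)ethyl in place of 1-methylpyrrolidin-3-yl on a saturated chain carbon bound to an aromatic nitrogen. Among the measured compounds shown here, two measured steps bear on this. The step of a 1.6-fold lower number from compound 1 to compound 3 (0.20 log units; within the scatter) shows that the ring in place of the open chain moved the number only within the scatter. The step of a 2.0-fold higher number from compound 1 to compound 2 (0.30 log units; within the scatter) shows that another ring, with a longer link, also stayed within the scatter. Compound 4 reverses the ring closure of compound 3 and adds one chain carbon beyond compound 1, so for compound 4 the expected step is a 1.8-fold higher number from compound 3 to compound 4 (0.26 log units; within the scatter), towards a somewhat higher number but plausibly within the scatter. The expected value for compound 4 in this assay is therefore 180 nM, between 70 nM and 450 nM.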

Compound 4, inhibition constant: 316 nM
For compound 4 the middle estimate is 1.8-fold (0.24 log units) below the measured one; measured number inside the range.
By their numbers in this assay, from the lowest: compounds 3, 1, 2 and 4 (each within the scatter of the next, the first and the last beyond it).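

In this assay, replacing 1-methylpyrrolidin-3-yl with 2-(dimethylamino)ethyl gives a step beyond the scatter (a 3.2-fold higher number from compound 3 to compound 4 (0.50 log units; beyond the scatter)), so this ring and this longer open chain can be told apart at this position. The added chain carbon alone stays within the scatter (a 2.0-fold higher number from compound 1 to compound 4 (0.30 log units; within the scatter)), and the longer open chain reads the same as the ring-bearing compound 2 (no change at the digits printed from compound 2 to compound 4 (within the scatter)), so among these compounds only the ring of compound 3 stands clearly apart from both longer-linked amines. No available measurement explains this gap.

On these data alone, it remains open whether a piperidine ring in place of the pyrrolidine would stay close to compound 3. As far as these compounds go, it is equally open how a still longer chain ending in dimethylamino, or a primary amine at its end, would read.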